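A few compounds are considered here, and "the series" means these few. Any claim that something is new, unique, unknown or untested is made for them only; others in the source may bear on it.

Working notes on the series. Within the data shown here, in a functional assay on DU-145 cells (Homo sapiens) for inhibition, read by trypan blue exclusion, with a stated time of 96 h (a lower number here means a stronger inhibitor of growth, a higher number a weaker inhibitor of growth), compound 3 (`COc1ccc(/C=C(/SCc2ccc(Cl)cc2)C(=O)c2ccc(Br)cc2)cc1`) gives 10000 nM, the higher of the two true numbers so far. Compound 2 (`O=C(O)c1ccc(C(=O)/C(=C\c2ccc(Cl)c([N+](=O)[O-])c2)SCc2ccc(Cl)cc2)cc1`) gives the lower number, 1000 nM. Compound 1 (`O=C(O)c1ccc(/C=C(/SCc2ccc(Cl)cc2)C(=O)c2ccc(C(=O)O)cc2)cc1`) gives > 100000 nM, which is a limit of the assay and not a number.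

The next step leads to compound 4 (`COc1ccc(/C=C(/SCc2ccc(Cl)cc2)C(=O)c2ccc(C(=O)O)cc2)cc1`), with carboxy in place of bromo on an aromatic carbon, para to a large group: carboxy in place of bromo on an aromatic carbon. Among the measured compounds shown here, no measured step makes this same change, so the evidence is indirect. The closest is an at least 100-fold lower number from compound 1 to compound 2 (2.00 log units; beyond the scatter), where a 4-carboxyphenyl group gives way to 4-chloro-3-nitrophenyl on the chain. That step suggests a carboxy-bearing ring can cost a great deal in this assay. Against this, compound 2 still carries a 4-carboxyphenyl group and reaches 1000 nM, so that group alone does not force a high number.

A moderate move toward a higher number therefore seems likely, much smaller than the step from compound 1 to compound 2, and a limit remains possible. The expected change is a 2.5-fold higher number from compound 3 to compound 4 (0.40 log units; beyond the scatter). For compound 4 the estimated value is 25000 nM, with an expected range from 5000 nM to 100000 nM.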

Compound 4, concentration for 50% growth inhibition: 10000 nM
Compound 4: middle estimate off by 2.5-fold (0.40 log units), on the high side; measured number inside the range.
By their numbers in this assay, from the lowest: compound 2; then compounds 3 and 4 (each within the scatter of the next). At a limit, above all of these: compound 1.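

In this assay, the change at this aromatic carbon, para to a large group, gives no change at the digits printed from compound 3 to compound 4 (within the scatter), so with 4-methoxyphenyl on the chain, the 4-carboxyphenyl group reads the same as the 4-bromophenyl group. The number instead follows the group on the chain and the group that replaces carboxy there: the series shows a 10-fold higher number from compound 2 to compound 4 (1.00 log units; beyond the scatter) and an at least 10-fold lower number from compound 1 to compound 4 (1.00 log units; beyond the scatter), so the large cost suggested by the earlier step does not come from the 4-carboxyphenyl group shared by compounds 1, 2 and 4. The second of these steps gives only a bound on its size, since compound 1 stands at a limit of the assay and not at a number: the limit of > 100000 nM in this assay, at which 1 of the 4 values shown sits.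

The compounds shown leave open whether bromo and carboxy would also read alike with 4-chloro-3-nitrophenyl on the chain, since only one such pair is available, and that pair carries 4-methoxyphenyl. They also leave open whether an amine or a methyl ester on this aromatic carbon would give the same number as bromo and carboxy, or would move it beyond the scatter.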